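Chloro to amino exchange on the core of compound 2

The source may report more compounds than this note shows. Statements on the series, on what has been measured and on what is new or still open speak of the compounds shown alone.

compound 1 `ClCc1ccc(Cn2cnc3c(Cl)ncnc32)cc1`: 72400 nM
compound 2 `ClCc1ccccc1Cn1cnc2c(Cl)nc(Cl)nc21`: 1620 nM
compound 3 `ClCc1cccc(Cn2cnc3nc(Cl)nc(Cl)c32)c1`: 2880 nM

In a functional assay on PC-3 cells (Homo sapiens) for cytotoxicity, read by sulforhodamine B assay, with a stated time of 48 h (on this read-out higher numbers stand for weaker inhibition of growth and lower numbers for stronger inhibition of growth), compound 2 gives 1620 nM, the lowest of the three numbers. Compound 3 gives 2880 nM, which lies within the scatter of compound 2, so no order between these two can be read. Compound 1 gives 72400 nM, a number beyond the scatter of compound 2 and the furthest of the three from it; compound 1 differs from compound 2 in more than one place, so this gap is not a single step.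

Compound 4 `Nc1nc(Cl)c2ncn(Cc3ccccc3CCl)c2n1` is not yet measured. It differs from compound 2 in this way: amino in place of chloro on an aromatic carbon, between two ring nitrogen atoms of the core. Among the measured compounds shown here, no measured pair in this set shows this exchange, so no step size can be taken from the numbers. The step is expected to be a 3.1-fold higher number from compound 2 to compound 4 (0.49 log units; beyond the scatter), a modest move toward a higher number. Compound 4 is estimated at 5000 nM, with a range from 1500 nM to 20000 nM.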

Compound 4, concentration for total growth inhibition: 67600 nM
Compound 4: the middle estimate sits 14-fold (1.13 log units) below what was measured; measured number outside the range, above it.
By their numbers in this assay, from the lowest: compounds 2 and 3 (each within the scatter of the next); then compounds 4 and 1 (each within the scatter of the next).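

Among the compounds shown here, the exchange of chloro for amino on an aromatic carbon, between two ring nitrogen atoms, gives the first single-place step: in this assay it is a 42-fold higher number from compound 2 to compound 4 (1.62 log units; beyond the scatter), a large move toward weaker inhibition of growth. For the compounds shown here, the earlier compounds all differed from one another in more than one place, and only this pair ties a change in the number to this position. In this one pair, amino does not stand in for chloro at this position, and no measurement at hand accounts for the size of the step.

On these data alone, whether other groups at this position, such as methylamino, methoxy or a plain hydrogen, fall nearer to compound 2 or to compound 4 stays open. Also open, as far as these compounds go, is whether the same exchange on the other chloro of the core gives a step of similar size.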